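This account rests on a few compounds, and the source may have more. Where it says the series, first, only, none or still open, it means among the compounds named here.

Compound 1 (`O=S(=O)(Nc1ccc(-c2nc3ccccc3o2)cc1)c1ccccc1O`) is measured in an assay on cells for inhibition of HSP60/HSP10 (Homo sapiens), with a stated time of 60 min; on this read-out lower numbers stand for stronger inhibition and higher numbers for weaker inhibition. In this assay compound 1 gives > 100000 nM, which is a limit of the assay rather than a number. Compound 2 (`Cc1cccc(S(=O)(=O)Nc2ccc3oc(-c4ccccc4)nc3c2)c1`) likewise reaches only a limit in this assay, > 100000 nM. Compound 3 (`C=Cc1ccc(S(=O)(=O)Nc2ccc3oc(-c4ccccc4)nc3c2)cc1`) also gives a limit in this assay, > 100000 nM. Within the data shown here, the single comparison between measured compounds, a step that the two limits leave unreadable from compound 2 to compound 3, cannot be read in size or direction, since all three values sit at the limit of > 100000 nM in this assay, at which 3 of the 3 values shown sit. Compound 4 (`CS(=O)(=O)Nc1ccc(-c2nc3ccccc3o2)cc1`) differs from compound 1 by methyl in place of 2-hydroxyphenyl on a sulfonyl sulfur. Among the measured compounds shown here, no measured step bears on this position, so no direction can be read for it. Compound 4 is therefore expected at 100000 nM (range 30000 nM to 300000 nM), most probably again as a limit. The step this estimate implies, a number no higher from compound 1 to compound 4 (the limit leaves the size open), is expected to stay within the scatter.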

Compound 4, half-maximal inhibitory concentration: > 100000 nM
Compound 4 gave a limit, no number (the forecaster's own chance of this, stated with the estimate: 85%); the middle value lies on the limit itself.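

Compound 1 and compound 4 both give limits rather than numbers, so no step can be read between them: the limit of > 100000 nM in this assay, at which 4 of the 4 values shown sit.
The compounds shown leave open which change, if any, brings a measurable number in this assay at all.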